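Cyanopyridinyl replaces pyrimidinyl in thienopyrimidine amines

The compounds below may be only part of what the source reports. "The series", "measured", "known", "first", "only" and "open" are said of these compounds alone.

Measured so far:
compound 1 `N#Cc1cccc(-c2nc(N)c3cc(Cc4ccccc4)sc3n2)c1`, 222 nM
compound 2 `Nc1nc(-c2ncccn2)nc2sc(Cc3ccccc3)cc12`, 618 nM

Of the compounds shown here, two have been measured in a functional assay on CHO-K1 cells for antagonist activity at adenosine receptor A1 (Homo sapiens), read by a beta-galactosidase reporter and cAMP accumulation, with stated times of 15 min and 6 h; on this read-out lower numbers stand for stronger inhibition and higher numbers for weaker inhibition. Compound 1 `N#Cc1cccc(-c2nc(N)c3cc(Cc4ccccc4)sc3n2)c1` gives 222 nM, and compound 2 `Nc1nc(-c2ncccn2)nc2sc(Cc3ccccc3)cc12` gives 618 nM. Going by the values given here, compound 2 thus stands at the higher of the two numbers; the single measured step, a 2.8-fold higher number from compound 1 to compound 2 (0.44 log units; beyond the scatter), arises from putting pyrimidin-2-yl in place of 3-cyanophenyl on an aromatic carbon of the shared core.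

Compound 3 `N#Cc1cncc(-c2nc(N)c3cc(Cc4ccccc4)sc3n2)c1` has not yet been measured. It differs from compound 2 in one place: 5-cyanopyridin-3-yl in place of pyrimidin-2-yl on an aromatic carbon. Among the compounds with values here, the only step that bears on this change is the reverse of the measured one, since 5-cyanopyridin-3-yl carries the nitrile that 3-cyanophenyl carries in compound 1, while pyrimidin-2-yl in compound 2 lacks it. That step, a 2.8-fold higher number from compound 1 to compound 2 (0.44 log units; beyond the scatter), was modest but beyond the scatter, so a move back toward the number of compound 1 in this assay is expected, with the step estimated as a 2.1-fold lower number from compound 2 to compound 3 (0.31 log units; beyond the scatter). For compound 3 the expected value in this assay is therefore 300 nM, within a range from 120 nM to 750 nM.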

Compound 3, inhibition constant: 1160 nM
For compound 3 the middle estimate is 3.9-fold (0.59 log units) below the measured one; measured number outside the range, above it.
By their numbers in this assay, from the lowest: compound 1; then compounds 2 and 3 (each within the scatter of the next).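

The nitrile alone does not keep a compound near compound 1 in this assay: 5-cyanopyridin-3-yl carries it just as 3-cyanophenyl does, yet the exchange gives a 5.2-fold higher number from compound 1 to compound 3 (0.72 log units; beyond the scatter), so on this aromatic carbon, between two ring nitrogen atoms, a single change of the ring from 3-cyanophenyl to 5-cyanopyridin-3-yl is enough to produce a step beyond the scatter. Nor does the nitrile set the pyridine compound apart from the pyrimidine: the exchange of pyrimidin-2-yl for 5-cyanopyridin-3-yl gives a 1.9-fold higher number from compound 2 to compound 3 (0.27 log units; within the scatter), so compounds 2 and 3 cannot be told apart here, and among the three groups only 3-cyanophenyl stands out, with compound 1 holding the lowest number. Nothing available explains these differences.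

The compounds shown leave open whether an unsubstituted phenyl at this position would stay close to compound 1, which would show how much of its number depends on the nitrile. They also leave open whether a carboxylic acid or a methoxy group in place of the nitrile on the phenyl ring would hold that number.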